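The source may report more compounds than this note shows. Statements on the series, on what has been measured and on what is new or still open speak of the compounds shown alone.

Compound 1 `COc1ccc(S(=O)(=O)N2CCc3cccc(-c4ccc(F)nc4)c32)cc1` carries a 6-fluoropyridin-3-yl group on the shared core, and in a functional assay on KB-VIN10 cells (Homo sapiens) for inhibition, with a stated time of 72 h (a lower number here means a stronger inhibitor, a higher number a weaker inhibitor), compound 1 gives 151 nM, the highest of the three numbers measured. Compound 2 `COc1ccc(S(=O)(=O)N2CCc3cccc(-c4ccco4)c32)cc1` gives 79.2 nM and compound 3 `COc1ccc(S(=O)(=O)N2CCc3cccc(-c4ccc(F)c(F)c4)c32)cc1` gives 46 nM. Compound 4 `COc1ccc(S(=O)(=O)N2CCc3cccc(-c4cccc(F)c4)c32)cc1` is not yet measured; it differs from compound 1 in one place: 3-fluorophenyl in place of 6-fluoropyridin-3-yl on an aromatic carbon. The related steps are a 1.9-fold lower number from compound 1 to compound 2 (0.28 log units; within the scatter) and a 3.3-fold lower number from compound 1 to compound 3 (0.52 log units; beyond the scatter), so swapping this ring for another aromatic group has lowered the number each time, clearly so for a fluorine-bearing carbon ring. For compound 4 a modest drop is therefore expected, a 2.5-fold lower number from compound 1 to compound 4 (0.40 log units; beyond the scatter). The estimate for compound 4 is 60 nM, expected to lie between 25 nM and 150 nM.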

Compound 4, half-maximal inhibitory concentration: 92.4 nM
Estimate against measurement, compound 4: 1.5-fold (0.19 log units) below; measured number inside the range.
By their numbers in this assay, from the lowest: compounds 3, 2, 4 and 1 (each within the scatter of the next, the first and the last beyond it).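

Swapping 6-fluoropyridin-3-yl for 3-fluorophenyl gives a 1.6-fold lower number from compound 1 to compound 4 (0.21 log units; within the scatter), so a carbon-only ring with a single fluoro group does not by itself separate from the pyridine compound. Going from 3,4-difluorophenyl to 3-fluorophenyl gives a 2.0-fold higher number from compound 3 to compound 4 (0.30 log units; within the scatter), and going from furan-2-yl gives a 1.2-fold higher number from compound 2 to compound 4 (0.07 log units; within the scatter), so compound 4 cannot be told apart from either. Only compound 3 stands beyond the scatter from compound 1, and no measured evidence here explains these numbers. Still open, on these data alone, is how this position would respond to a non-aromatic group, such as an amine, a carboxylic acid or a longer chain.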